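A few compounds are considered here, and "the series" means these few. Any claim that something is new, unique, unknown or untested is made for them only; others in the source may bear on it.

Measured so far, in an assay on isolated protein for binding affinity to leukotriene B4 receptor 1 (Homo sapiens), tested at 1 uM; a higher number here means more inhibition at the concentration tested (going by the name of the read-out), a lower number less inhibition:
compound 1, `CCc1cc(C(C)=O)c(O)cc1OCCCCCC(C)(C)C#N`: 53%
compound 2, `CCc1cc(C(C)=O)c(O)cc1OCCCCCC(C)(C)c1nnnn1C`: 59%
compound 3, `CCc1cc(C(C)=O)c(O)cc1OCCCCCCC(=O)O`: 38%

Compound 3 gives the lowest of these three numbers. Its chain ends in a carboxy group, and the two steps leading to it both fall: a number 15 percentage points lower from compound 1 to compound 3 (beyond the scatter) and a number 21 percentage points lower from compound 2 to compound 3 (beyond the scatter). Between compound 1 and compound 2, by contrast, the change of the end group gives a number 6 percentage points higher from compound 1 to compound 2 (within the scatter).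

Compound 4, `CCc1cc(C(C)=O)c(O)cc1OCCCCCCc1nnn[nH]1`, is not yet measured. It differs from compound 3 in one place: 1H-tetrazol-5-yl in place of carboxy on a saturated chain carbon, six bonds along the chain from an oxygen on an aromatic ring. The step from compound 2 to compound 3 is the one that bears most on this, since there a tetrazolyl-bearing end group gave way to a carboxy group and the number dropped by a modest amount beyond the scatter. Compound 4 reverses the sense of that swap, although its tetrazolyl ring carries no methyl and sits directly on the chain. A rise is therefore expected, of about a number 14 percentage points higher from compound 3 to compound 4 (beyond the scatter). For compound 4 the expected value in this assay is 52%, within a range of 32% to 70%.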

Compound 4, a percentage reported as inhibition, at one concentration (the size of the read-out at that concentration, not a potency): 60%
Estimate against measurement, compound 4: 8 percentage points below; measured number inside the range.
By their numbers in this assay, from the lowest: compound 3; then compounds 1, 2 and 4 (each within the scatter of the next).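

In this assay, exchanging carboxy for 1H-tetrazol-5-yl at this chain end, with nothing else altered, gives a number 22 percentage points higher from compound 3 to compound 4 (beyond the scatter) and so tests these two end groups directly on the same chain. The plain tetrazole on the unbranched chain also matches the branched end groups: a number 1 percentage points higher from compound 2 to compound 4 (within the scatter) and a number 7 percentage points higher from compound 1 to compound 4 (within the scatter) both lie within the scatter, which shows that neither the chain branching nor the methyl on the ring of compound 2 is needed to reach this level. The data shown offer no explanation for the gap between the carboxy and tetrazole compounds.

From the compounds shown here alone, it remains open how a methyl ester or a primary amide at the chain end would compare, and whether a longer chain would keep the tetrazole's level. Going by these compounds, each figure is a reading at one concentration, so true potencies remain unknown.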